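A few compounds are considered here, and "the series" means these few. Any claim that something is new, unique, unknown or untested is made for them only; others in the source may bear on it.

Compound 1 `Cc1cccc(Nc2nccc(-c3cc(C)oc3C)n2)c1`, compound 2 `Cc1cccc(Nc2nccc(-c3ccc(C)o3)n2)c1` and compound 3 `CCN(CC)c1ccc(Nc2nccc(-c3ccc(C)o3)n2)cc1` have been measured in a functional assay for inhibition, with Homo sapiens as the target; on this read-out higher numbers stand for weaker inhibition and lower numbers for stronger inhibition. Compound 2 gives 2000 nM, compound 1 gives 28500 nM and compound 3 gives 28000 nM in this assay. The step of a 14-fold higher number from compound 2 to compound 1 (1.15 log units; beyond the scatter) goes with the change (2,5-dimethylfuran-3-yl in place of 5-methylfuran-2-yl on an aromatic carbon). Compound 3 differs from compound 2 in its core; the difference between the two cores is not broken down here. The values of compound 3 and compound 1 lie within the scatter of each other. Compound 4 `CCN(CC)c1ccc(Nc2nccc(-c3cc(C)oc3C)n2)cc1` is not yet measured; it arises from compound 3 by 2,5-dimethylfuran-3-yl in place of 5-methylfuran-2-yl on an aromatic carbon, the same kind of change as from compound 2 to compound 1, but meta to a large group rather than meta to a group of 8 heavy atoms. A step of a 7.1-fold higher number from compound 3 to compound 4 (0.85 log units; beyond the scatter) is expected beside a 14-fold higher number from compound 2 to compound 1 (1.15 log units; beyond the scatter), resting on compound 2 passing to compound 1 with a 14-fold higher number from compound 2 to compound 1 (1.15 log units; beyond the scatter). Compound 4 is therefore estimated at 200000 nM, between 40000 nM and 800000 nM, in this assay.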

Compound 4, half-maximal inhibitory concentration: > 24000 nM
Compound 4 was reported as a limit (the forecaster's own chance of this, stated with the estimate: 40%); the middle value does not contradict the limit.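

Within the data shown here, compound 4 is reported only as a limit, > 24000 nM, so no step from compound 3 to compound 4 can be read. The compounds shown leave open whether 2,5-dimethylfuran-3-yl in place of 5-methylfuran-2-yl raises the number on the core of compound 3 as it does on the core of compound 2.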